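This account rests on a few compounds, and the source may have more. Where it says the series, first, only, none or still open, it means among the compounds named here.

Measured in a functional assay on A549 cells (Homo sapiens) for cytotoxicity, read by MTT assay, with a stated time of 72 h; on this read-out higher numbers stand for weaker inhibition and lower numbers for stronger inhibition:
Compound 1 `COc1ccc(/C=C/C(=O)Nc2cc3c(Nc4ccc(F)c(Cl)c4)ncnc3cc2OC)cc1`: "not active" (no number reported)
Compound 2 `N#Cc1ccc(/C=C/C(=O)Nc2cc3c(Nc4ccc(F)c(Cl)c4)ncnc3cc2O[C@H]2CCOC2)cc1`: "not active" (no number reported)
Compound 3 `COc1cc(/C=C/C(=O)Nc2cc3c(Nc4ccc(F)c(Cl)c4)ncnc3cc2O[C@H]2CCOC2)cc(OC)c1O`: 27000 nM

Compound 3, at 27000 nM, is the only one of the three with a number, and that number is the sole reference point. Compound 4 `COc1ccc(/C=C/C(=O)Nc2cc3c(Nc4ccc(F)c(Cl)c4)ncnc3cc2O[C@H]2CCOC2)cc1` has not been measured yet. It differs from compound 3 as follows: 4-methoxyphenyl in place of 4-hydroxy-3,5-dimethoxyphenyl on a double-bonded chain carbon bound to a double-bonded chain carbon. Going by the values given here, no measured pair shows what this change does on its own, so any expectation is loose. Compound 1 also carries 4-methoxyphenyl and gave "not active" (no number reported), which points toward weaker inhibition, and a result without a number is quite possible. In this assay a small step in that direction is expected, estimated as a 1.7-fold higher number from compound 3 to compound 4 (0.22 log units; within the scatter). Compound 4 is expected at 45000 nM, with an estimated range of 15000 nM to 100000 nM.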

Compound 4, half-maximal inhibitory concentration: 3050 nM
The estimate for compound 4 lay 15-fold (1.17 log units) above the measured number; the measured number lies below the stated range.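

In this assay, this position clearly affects the result, with an 8.9-fold lower number from compound 3 to compound 4 (0.95 log units; beyond the scatter). Going by these compounds alone, replacing 4-hydroxy-3,5-dimethoxyphenyl with 4-methoxyphenyl on the double-bonded chain carbon therefore strengthens inhibition in this pair, and the earlier compounds alone could not show this. Nothing measured here explains the gain. The steps involving compound 1 and compound 2 cannot be read, as neither has a number. From the compounds shown here alone, it remains open whether the hydroxy group or the extra methoxy groups account for the change, and what a 4-aminophenyl group would give at this position.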